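From a free hydroxy to a sulfone chain

The compounds below may be only part of what the source reports. "The series", "measured", "known", "first", "only" and "open" are said of these compounds alone.

- compound 1 `CCOc1ccc(-c2cccc(CNc3ccc(OCC(=O)O)c(F)c3)c2)c(C)c1`: 2.83
- compound 2 `CCCOc1ccc(-c2cccc(CNc3ccc(OCC(=O)O)c(F)c3)c2)c(C)c1`: 3.37
- compound 3 `Cc1cc(O)ccc1-c1cccc(CNc2ccc(OCC(=O)O)c(F)c2)c1`: 1.85

These values come from a physicochemical assay for lipophilicity, read by HPLC, in phosphate buffer, measured as octanol-water partition, at pH 7.4, tested at 100 uM; a lower number here means a more polar compound, a higher number a more lipophilic compound. Of the three compounds, compound 3 stands lowest, at 1.85. The next structure, compound 4 `Cc1cc(OCCCS(C)(=O)=O)ccc1-c1cccc(CNc2ccc(OCC(=O)O)c(F)c2)c1`, puts 3-(methylsulfonyl)propyl in place of hydrogen on an oxygen on an aromatic ring.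

Going by the values given here, three measured steps bear on this change. Removing the chain gave a number 0.98 log units lower from compound 1 to compound 3 (beyond the scatter) and a number 1.52 log units lower from compound 2 to compound 3 (beyond the scatter), while lengthening it gave a number 0.54 log units higher from compound 1 to compound 2 (beyond the scatter). Among these three compounds, a plain chain on that oxygen therefore goes with a higher number, and a longer chain with a higher one still. However, no measured compound carries a methylsulfonyl group, so these steps are only a loose guide. In this assay, a small upward step is expected, one that may stay within the usual scatter, and much smaller than the plain propyl step. The expected change is a number 0.25 log units higher from compound 3 to compound 4 (within the scatter). For compound 4 the estimate is 2.1, with an expected range from 1.6 to 2.7.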

Compound 4, distribution coefficient: 1.59
Compound 4: middle estimate off by 0.51 log units, on the high side, outside the stated range (below it).
By their numbers in this assay, from the lowest: compounds 4 and 3 (each within the scatter of the next); then compound 1; then compound 2.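

In this assay the 3-(methylsulfonyl)propyl chain on the oxygen gives a number 0.26 log units lower from compound 3 to compound 4 (within the scatter) and so cannot be told apart from the free hydroxy. Set against the plain chains, the same compound sits well away, with a number 1.78 log units lower from compound 2 to compound 4 (beyond the scatter) for the propyl ether and a number 1.24 log units lower from compound 1 to compound 4 (beyond the scatter) for the ethyl ether. Among these four compounds, then, a chain on this oxygen does not by itself go with a higher number: compound 1 and compound 2 fit that reading, while compound 4 goes against it.

From the compounds shown here alone, it remains open whether a shorter chain ending in methylsulfonyl, or a propyl chain ending in an amine or a carboxylic acid, would also stay with the free hydroxy. No measurement at hand explains the result for compound 4.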